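The source may report more compounds than this note shows. Statements on the series, on what has been measured and on what is new or still open speak of the compounds shown alone.

Compound 2 `CN1CCC(CCn2c(N)nc3ccc(C(=O)c4ccccc4)cc32)CC1` shows no measurable effect within the window of an ADME assay on HL-60 cells (Homo sapiens) for cytotoxicity, read by resazurin assay, with a stated time of 72 h; on this read-out lower numbers stand for an effect already at smaller amounts and higher numbers for an effect only at larger amounts of compound: in this assay compound 2 gives only a limit, > 30000 nM. Compound 1 `O=C(NCCC1CCNCC1)Nc1nc2ccc(C(=O)c3ccccc3)cc2[nH]1` likewise gives only a limit in this assay, > 30000 nM. Among the compounds with values here, both values shown sit at the limit of > 30000 nM in this assay, at which 2 of the 2 values shown sit, so no step between them can be read and the series so far carries no size information. Compound 3 `CN1CCC[C@@H]1Cn1c(N)nc2ccc(C(=O)c3ccccc3)cc21` differs from compound 2 by 1-methylpyrrolidin-2-yl in place of (1-methylpiperidin-4-yl)methyl on a saturated chain carbon bound to an aromatic nitrogen. With every shown value at the limit, the expected step from compound 2 to compound 3 is a step that the limit leaves unreadable from compound 2 to compound 3, none beyond the scatter. Compound 3 is therefore estimated at 40000 nM, between 15000 nM and 120000 nM, and is expected most likely to be reported again only as a limit.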

Compound 3, half-maximal effective concentration: > 30000 nM
Compound 3 gave a limit, no number; the forecaster's own chance of this, stated with the estimate: 80%; the middle value lies beyond the limit too.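

In this assay, within the data shown here, compound 3 gives only a limit, > 30000 nM, and no step from compound 2 to compound 3 can be read. The compounds shown leave open whether 1-methylpyrrolidin-2-yl in place of (1-methylpiperidin-4-yl)methyl changes this read-out at all.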